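Shortening the Side Chain in a Series Without Activity

This account rests on a few compounds, and the source may have more. Where it says the series, first, only, none or still open, it means among the compounds named here.

Three compounds share one core and were tested in a functional assay on the whole organism (strain Swiss) with Mus musculus as the target, in the maximal electroshock model, with a stated time of 2 h, at a dose of 100 mg/kg by the intraperitoneal route; a lower number here means a weaker effect, a higher number a stronger effect of the compound at the dose given. Compound 1 `CC(C(=O)N1CCN(c2ccccc2)CC1)N1C(=O)CCC1=O` gives 0% in this assay. Compound 2 `CC(C(=O)N1CCN(c2cccc(F)c2)CC1)N1C(=O)CCC1=O` gives 0%, so the step from compound 1 to compound 2, a fluoro in place of hydrogen on an aromatic carbon, reads no change at the digits printed from compound 1 to compound 2 (within the scatter). Going by the values given here, compound 3 `CCC(C(=O)N1CCN(c2cccc(C(F)(F)F)c2)CC1)N1C(=O)CCC1=O` gives 0% and therefore stands level with compound 1 and compound 2; no compound of the three can be called stronger or weaker than another.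

Compound 4 `CC(C(=O)N1CCN(c2cccc(C(F)(F)F)c2)CC1)N1C(=O)CCC1=O` is the next compound. It differs from compound 3 in one place only: hydrogen in place of methyl on a saturated chain carbon, two bonds along the chain from an amide-type nitrogen in a ring and a carbonyl carbon. Among the compounds with values here, only one measured step exists, and it concerns a change on an aromatic carbon rather than on the chain, so it gives no direct guidance on this change beyond showing that the read-out stayed flat. Compound 1, which carries a methyl on the chain and no group on the aromatic ring, and compound 3, which carries an ethyl and a trifluoromethyl, show the same value in this assay, so the chain length has so far made no visible difference. The step from compound 3 to compound 4 is expected to be no change at the digits printed from compound 3 to compound 4 (within the scatter), which means no change beyond the scatter. For compound 4 the estimated value in this assay is 0%, with a range from 0% to 10%.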

Compound 4, a percentage reported as activity, at one dose (the size of the read-out at that dose, not a potency): 0%
For compound 4 middle estimate and measured number coincide at the digits printed; measured number inside the range.
By their numbers in this assay, from the lowest: compounds 1, 2, 3 and 4 (each within the scatter of the next).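

In this assay, the saturated chain carbon now has a direct reading of its own: cutting ethyl back to methyl there, with everything else held constant, gives a step that reads (no change at the digits printed from compound 3 to compound 4 (within the scatter)). With the methyl chain kept, the aromatic carbon can also be read apart from any chain difference: trifluoromethyl in place of hydrogen reads (no change at the digits printed from compound 1 to compound 4 (within the scatter)), and trifluoromethyl in place of fluoro reads (no change at the digits printed from compound 2 to compound 4 (within the scatter)). No measurement is available that would explain these readings.

The compounds shown leave open whether a longer chain, such as butyl, on the saturated chain carbon, or an amine or a carboxylic acid on the aromatic carbon, would read any differently in this assay. It also remains open whether any change at these two places can move the shared core away from the reading seen so far, and none of the groups shown can yet be ranked against another.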